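Inverting One Ring Stereocentre in a Weak Antagonist

A few compounds are considered here, and "the series" means these few. Any claim that something is new, unique, unknown or untested is made for them only; others in the source may bear on it.

Measured so far:
Compound 1 `N=C(N)NCCCCNC(=O)/C=C/c1ccc2c(c1)[C@@H](C(=O)NCCCCNC(=N)N)[C@H](c1ccc(O)cc1)O2` gives 14300000 nM in a functional assay on Caudal artery for antagonist activity at Alpha-1A adrenergic receptor (Rattus norvegicus); on this read-out lower numbers stand for stronger inhibition and higher numbers for weaker inhibition.
Compound 2 `COC(=O)[C@@H]1c2cc(/C=C/C(=O)NCCCCNC(=N)N)ccc2O[C@H]1c1ccc(O)cc1` gives 9720000 nM in this assay.

Among the measured compounds shown here, compound 1 stands at the highest of the two numbers, and its only neighbour is compound 2 at a 1.5-fold lower number from compound 1 to compound 2 (0.17 log units; within the scatter). Compound 3 `N=C(N)NCCCCNC(=O)/C=C/c1ccc2c(c1)[C@H](C(=O)NCCCCNC(=N)N)[C@H](c1ccc(O)cc1)O2` differs from compound 1 only as follows: the two compounds have the same atoms and bonds; at least one stereo element is drawn with a configuration in one of them and without one in the other: 1 of 5 stereo elements differ; a stereocentre at a saturated ring carbon is drawn R in compound 1 and S in compound 3. For the measured compounds named here, no measured step changes a stereocentre, so none bears on this change. With nothing to guide a direction, compound 3 is expected to land close to compound 1, a step of a 1.0-fold lower number from compound 1 to compound 3 (0.01 log units; within the scatter). The estimate for compound 3 in this assay is 14000000 nM, between 3000000 nM and 60000000 nM.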

Compound 3, half-maximal inhibitory concentration: 4900000 nM
The estimate for compound 3 lay 2.9-fold (0.46 log units) above the measured number; the measured number falls inside the stated range.
By their numbers in this assay, from the lowest: compounds 3, 2 and 1 (each within the scatter of the next, the first and the last beyond it).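

Among the compounds shown here, until now no step touched a stereocentre. Here the atoms and bonds stay the same and only the configuration at one saturated ring carbon changes, yet the number in this assay moves by a modest step beyond the scatter, a 2.9-fold lower number from compound 1 to compound 3 (0.47 log units; beyond the scatter). One caution applies to reading this as a clean inversion: the fact that one of compounds 1 and 3 is drawn with a defined configuration and the other without, at the place where they differ

Still open, on these data alone, is whether the same inversion would shift the number for compound 2, which carries the methyl ester. As far as these compounds go, it is also open whether a carboxylic acid on that carbonyl carbon would respond to this configuration in the same way.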